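Working notes: biaryl change at the core, compound 3 to compound 4

This account rests on a few compounds, and the source may have more. Where it says the series, first, only, none or still open, it means among the compounds named here.

Measured so far in a functional assay on KYSE-70 cells for antiproliferative activity against KYSE-70 cell line (Homo sapiens), read by MTT assay, with a stated time of 72 h; on this read-out higher numbers stand for weaker inhibition and lower numbers for stronger inhibition:
- Compound 1 `O=C(c1ccnc2cc(Br)ccc12)N1CCCCC1` gives only the assay limit > 20000 nM.
- Compound 2 `O=C(Nc1cccc(C(F)(F)F)c1)c1cc(=O)[nH]c2cc(Br)ccc12` gives only the assay limit > 20000 nM.
- Compound 3 `O=C(Nc1cccc(F)c1)c1cc(=O)[nH]c2cc(-c3ccc(F)cc3)ccc12` gives 3300 nM.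

Among the measured compounds shown here, compound 3 is the only compound of the three with a number in this assay; the other two sit at the limit of > 20000 nM in this assay, at which 2 of the 3 values shown sit, so no step between measured compounds can be sized here, and nothing can be said of how compound 3 compares with compound 1 or compound 2 beyond the fact that it has a value and they have limits.

Compound 4 `O=C(Nc1cccc(F)c1)c1cc(=O)[nH]c2cc(-c3cccnc3F)ccc12` differs from compound 3 in one place: 2-fluoropyridin-3-yl in place of 4-fluorophenyl on an aromatic carbon. Both groups carry a fluorine and keep the same count of heavy atoms; the change adds one hydrogen-bond acceptor through the ring nitrogen and nothing else.

With no measured step of this kind in the series, the expectation for compound 4 rests on compound 3 alone. The step of a 1.2-fold higher number from compound 3 to compound 4 (0.08 log units; within the scatter) is expected to stay within the usual scatter, in no firm direction. Compound 4 is estimated at 4000 nM, with a likely range from 1500 nM to 12000 nM.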

Compound 4, half-maximal inhibitory concentration: > 20000 nM
Compound 4 gave a limit, no number; the forecaster's own chance of this, stated with the estimate: 10%; middle value at least 5.0-fold (0.69 log units) from the limit.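

Among the compounds shown here, this is the first step that can be sized, and it shows that this aromatic carbon of the shared core does not tolerate every fluorinated six-membered aromatic ring: in this assay, 2-fluoropyridin-3-yl in place of 4-fluorophenyl gives an at least 6.0-fold higher number from compound 3 to compound 4 (0.78 log units; beyond the scatter). With the heavy-atom count unchanged, the two groups differ only in the ring nitrogen and its hydrogen-bond acceptor, together with where the fluorine sits, so a change this small is enough to lose the measurable value. The step is a minimum and not a full size, and compound 3 remains the only compound with a number: the limit of > 20000 nM in this assay, at which 3 of the 4 values shown sit.

Which feature of the entering ring carries the loss remains open. Neither pyridin-3-yl without fluorine nor 2-fluorophenyl is among the compounds shown, and either would separate the ring nitrogen from the fluorine placement.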